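The source may hold more compounds than are shown below. What is called first, only, known or untested is meant among the compounds shown, and "the series" means these compounds.

Measured compounds in this set:
compound 1 `O=C1COC(c2ccccc2)=NN1c1ccccc1` — 1.16 mL.min-1.g-1
compound 2 `O=C1CCC(c2ccccc2)=NN1c1ccccc1` — > 1.53 mL.min-1.g-1
compound 3 `O=c1ccc(-c2ccccc2)cn1-c1ccccc1` — > 1.53 mL.min-1.g-1

In an in vitro ADME assay on microsomes from liver (Mus musculus) for metabolic stability, read by LC-MS, with a stated time of 15 min (on this read-out lower numbers stand for slow clearance and higher numbers for fast clearance), compound 1 gives 1.16 mL.min-1.g-1. For compound 2 the result is a limit of the assay rather than a number, > 1.53 mL.min-1.g-1. For compound 3 the result is likewise only a limit, > 1.53 mL.min-1.g-1. Compound 3 therefore stands at the upper edge of what this assay reports, a position it shares with one other compound (the limit of > 1.53 mL.min-1.g-1 in this assay, at which 2 of the 3 values shown sit); no number places it with respect to compound 1 beyond that.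

Compound 4 `O=c1c(-c2ccccc2)cc(-c2ccccc2)cn1-c1ccccc1` has not been measured. It differs from compound 3 in one place: phenyl in place of hydrogen on an aromatic carbon. Among the compounds with values here, no step between measured compounds of this kind is available, so the expected step from compound 3 to compound 4 rests on the limit alone. The account expects a step that the limit leaves unreadable from compound 3 to compound 4 that stays within the scatter of the assay, with compound 4 most likely again reported at the limit. For compound 4 the estimate in this assay is 2 mL.min-1.g-1, ranging from 1.2 mL.min-1.g-1 to 3.5 mL.min-1.g-1.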

Compound 4, intrinsic clearance in microsomes: 0.148 mL.min-1.g-1
Beside the measured number, compound 4's estimate is 14-fold (1.13 log units) above it, outside the stated range (below it).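

In this assay, phenyl in place of hydrogen on an aromatic carbon, ortho to a group of 1 heavy atom, gives an at least 10-fold lower number from compound 3 to compound 4 (1.01 log units; beyond the scatter). Within the data shown here, the earlier compounds offered no readable step, so this is the first sign that this position matters for the read-out and that a change here can bring a compound clear of the limit. The full size of the step stays unknown, as the value for compound 3 is only a limit: the limit of > 1.53 mL.min-1.g-1 in this assay, at which 2 of the 4 values shown sit.

The compounds shown leave open whether this drop belongs to phenyl itself or would also come with a smaller group on the same carbon, such as a methyl, a methoxy or an amine. They also leave open whether phenyl at the matching place on the core of compound 1 or compound 2 would give a similar step.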